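The source may report more compounds than this note shows. Statements on the series, on what has been measured and on what is new or still open speak of the compounds shown alone.

Measured so far:
compound 1 `CC(C)(C)Cc1csc(N)c1C(=O)c1cccc(Cl)c1` gives 2% in an assay on CHO cells for displacement of a labelled ligand from adenosine receptor A1 (Homo sapiens), read by scintillation counting, tested at 10 uM; a lower number here means less inhibition, a higher number more inhibition at the concentration tested (going by the name of the read-out)
compound 2 `CC(C)(C)Cc1c(-c2ccoc2)sc(N)c1C(=O)c1ccc(Cl)cc1` gives 1% in this assay

Both numbers sit near zero and within the scatter of each other, so compound 2 stands with compound 1 at the bottom of a very short list. Compound 3 `COc1ccccc1-c1sc(N)c(C(=O)c2ccc(Cl)cc2)c1CC(C)(C)C` differs from compound 2 by 2-methoxyphenyl in place of furan-3-yl on an aromatic carbon. Nothing measured here shows that a group at that place moves the read-out, and both shared-core compounds sit at the floor of this assay. The step of a number 2 percentage points higher from compound 2 to compound 3 (within the scatter) is therefore expected to be none beyond the scatter, with compound 3 expected at 3%, range -5% to 14%.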

Compound 3, a percentage reported as inhibition, at one concentration (the size of the read-out at that concentration, not a potency): 1%
For compound 3 the middle estimate is 2 percentage points above the measured one; measured number inside the range.
By their numbers in this assay, from the lowest: compounds 2, 3 and 1 (each within the scatter of the next).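

At the aromatic carbon next to the ring sulfur, 2-methoxyphenyl in place of furan-3-yl gives no change at the digits printed from compound 2 to compound 3 (within the scatter) in this assay. Exchanging a five-membered aromatic ring for a six-membered one of carbon only therefore leaves the read-out near zero, so this change gives no handle on the series here. No measured evidence bears on this result. From the compounds shown here alone, whether an amine or a carboxylic acid at this carbon would lift the read-out stays open. So does the effect of replacing the neopentyl group with a shorter chain.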